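A few compounds are considered here, and "the series" means these few. Any claim that something is new, unique, unknown or untested is made for them only; others in the source may bear on it.

Measured in a functional assay on HT29-AK cells (Homo sapiens) for cytotoxicity, read by MTT assay, with a stated time of 48 h; a lower number here means a stronger inhibitor, a higher number a weaker inhibitor:
Compound 1 `Fc1cccc(-c2nc(Nc3ccccc3)c3cc(F)ccc3n2)c1` gives 48300 nM.
Compound 2 `Fc1cccc(-c2nc(Nc3ccc(Br)cc3)c3cc(F)ccc3n2)c1` reaches only a limit of the assay, > 50000 nM.
Compound 3 `Oc1ccc(Nc2nc(-c3cccc(F)c3)nc3ccc(F)cc23)cc1` likewise reaches only a limit, > 50000 nM.

Compound 3 thus stands at the limit of > 50000 nM in this assay, at which 2 of the 3 values shown sit, with no number of its own. Compound 4 `Oc1ccccc1Nc1nc(-c2cccc(F)c2)nc2ccc(F)cc12` differs from it by 2-hydroxyphenyl in place of 4-hydroxyphenyl on a nitrogen on an aromatic ring. Going by the values given here, the measured step that touches the hydroxyphenyl is an at least 1.0-fold higher number from compound 1 to compound 3 (0.01 log units; that floor lies within the scatter), and a step that the two limits leave unreadable from compound 2 to compound 3, so neither gives a readable size; the hydroxy group moving around the ring has no counterpart among the measured steps. Nothing here argues for a change beyond the scatter, and compound 4 is expected to sit near the same limit, the step of a number no higher from compound 3 to compound 4 (the limit leaves the size open) being a guess. The estimate for compound 4 in this assay is 50000 nM, within 15000 nM to 150000 nM.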

Compound 4, half-maximal inhibitory concentration: > 50000 nM
Compound 4: no number, only a limit; the forecaster's own chance of this, stated with the estimate: 60%; the middle value lies on the limit itself.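

In this assay compound 4 also reaches only a limit of the assay, > 50000 nM. Going by these compounds alone, the one readable new step is an at least 1.0-fold higher number from compound 1 to compound 4 (0.01 log units; that floor lies within the scatter), while the steps joining compound 4 to compound 2 and compound 3 cannot be read, so the change from (4-hydroxyphenyl)amino to (2-hydroxyphenyl)amino has no readable size. Neither hydroxyphenyl on this nitrogen yields a number in this assay, and the series now gathers at one limit: the limit of > 50000 nM in this assay, at which 3 of the 4 values shown sit.

On these data alone, whether an amine or a carboxylic acid in place of the hydroxy group would give a value short of that limit stays open. Any order among compound 2, compound 3 and compound 4 also stays open.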